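A Pyridin-3-yl Swap in an Antiproliferative Series

The source may hold more compounds than are shown below. What is called first, only, known or untested is meant among the compounds shown, and "the series" means these compounds.

Compound 1 `Cc1c(-c2cc(Cl)cc(Cl)c2)c(C(=O)O)nn1-c1nc(-c2cccnc2)c(SC(C)C)s1`: "not active" (no number reported)
Compound 2 `Cc1cc(C#N)cc(-c2c(C)nn(-c3nc(-c4ccc(Cl)c(Cl)c4)c(SC(C)C)s3)c2C(=O)O)c1`: 4800 nM
Compound 3 `COC(=O)c1c(Cc2ccccc2[N+](=O)[O-])c(C)nn1-c1nc(-c2ccc(Cl)c(Cl)c2)c(SC(C)C)s1`: 93000 nM

In a functional assay on BJAB cells (Homo sapiens) for antiproliferative activity, with a stated time of 4 days (a higher number here means that more compound is needed for the effect, a lower number that less compound is needed), compound 2 gives 4800 nM, the lowest of the two numbers recorded. Its nearest neighbour, compound 3, gives 93000 nM, a gap beyond the scatter. Compound 1 is reported as not active, with no number.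

Compound 4 `Cc1nn(-c2nc(-c3ccc(Cl)c(Cl)c3)c(SC(C)C)s2)c(C(=O)O)c1-c1cccnc1` differs from compound 2 in one place: pyridin-3-yl in place of 3-cyano-5-methylphenyl on an aromatic carbon. Going by the values given here, no measured pair isolates this change, so the size of the step is uncertain. Compound 1 carries pyridin-3-yl elsewhere and is not active, which offers no direct guide here. A modest loss, near the edge of the scatter, is expected.

Compound 4 is therefore estimated at 10000 nM, within 2500 nM to 40000 nM, a step of a 2.1-fold higher number from compound 2 to compound 4 (0.32 log units; beyond the scatter).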

Compound 4, half-maximal effective concentration: 12000 nM
Compound 4: the middle estimate sits 1.2-fold (0.08 log units) below what was measured; the measured number falls inside the stated range.
By their numbers in this assay, from the lowest: compound 2; then compound 4; then compound 3.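

Placed on the aromatic carbon that lies next to the ring atom bearing the carboxy group, pyridin-3-yl in place of 3-cyano-5-methylphenyl gives in this assay a 2.5-fold higher number from compound 2 to compound 4 (0.40 log units; beyond the scatter), a modest change. The position therefore keeps a measurable number with the smaller ring, without the nitrile and the methyl. No measurement at hand gives a reason for the step. Open, from the compounds shown here alone, is whether a plain phenyl ring here would read closer to compound 2 or compound 4, and whether an amine on the pyridine ring would change the number.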